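The source may hold more compounds than are shown below. What is called first, only, known or untested is meant among the compounds shown, and "the series" means these compounds.

Compound 3 `Cc1cc(C)c(-c2ccc(N)cn2)cc1NC(=O)c1ccc(OCc2ccccn2)cc1` stands lowest of the three numbers in an ADME assay on microsomes from liver (Rattus norvegicus) for metabolic stability (a lower number here means slower removal, a higher number faster removal of the compound), at 32 mL.min-1.g-1. Compound 1 `Cc1cc(C)c(-c2c(C)nn(C)c2C)cc1NC(=O)c1ccc(OCc2ccccn2)cc1` gives 271 mL.min-1.g-1 in this assay, and compound 2 `Cc1cc(C)c(-c2ccccn2)cc1NC(=O)c1ccc(OCc2ccccn2)cc1` gives 296 mL.min-1.g-1. The move from compound 3 to compound 4 `Cc1cc(C)c(-c2ccc(N)nn2)cc1NC(=O)c1ccc(OCc2ccccn2)cc1` is 6-aminopyridazin-3-yl in place of 5-aminopyridin-2-yl on an aromatic carbon. For the measured compounds named here, no measured step matches this change directly. Going by the values given here, the steps that bear on it are a 9.3-fold lower number from compound 2 to compound 3 (0.97 log units; beyond the scatter) and an 8.5-fold lower number from compound 1 to compound 3 (0.93 log units; beyond the scatter), both involving the amino group that compound 4 retains, whereas a 1.1-fold higher number from compound 1 to compound 2 (0.04 log units; within the scatter) shows two rings without that group lying within the scatter of each other. With the amino group kept and only the ring carrying it altered, a step of a 1.1-fold lower number from compound 3 to compound 4 (0.03 log units; within the scatter) is expected. Compound 4 is thus estimated at 30 mL.min-1.g-1 in this assay, within 12 mL.min-1.g-1 to 75 mL.min-1.g-1.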

Compound 4, intrinsic clearance in microsomes in the Rattus norvegicus assay: 8 mL.min-1.g-1
Estimate against measurement, compound 4: 3.8-fold (0.57 log units) above; measured number outside the range, below it.
By their numbers in the Rattus norvegicus assay, from the lowest: compound 4; then compound 3; then compounds 1 and 2 (each within the scatter of the next).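

In the Rattus norvegicus assay, the ring that carries the amino group proves to count at this position: 6-aminopyridazin-3-yl in place of 5-aminopyridin-2-yl gives a 4.0-fold lower number from compound 3 to compound 4 (0.60 log units; beyond the scatter), so keeping the amino group does not fix the number. In the Rattus norvegicus assay, the distance to the rings without that group reaches a 37-fold lower number from compound 2 to compound 4 (1.57 log units; beyond the scatter) and a 34-fold lower number from compound 1 to compound 4 (1.53 log units; beyond the scatter). In a physicochemical assay for solubility, at pH 7.4 (a higher number here means a more soluble compound, a lower number a less soluble compound), the same change gives an at least 6.0-fold higher number from compound 3 to compound 4 (0.77 log units; beyond the scatter), a step resting on a limit. In the physicochemical assay compound 4 gives 6000 nM. In the physicochemical assay compound 3 gives < 1000 nM, which is a limit of the assay and not a number: the limit of < 1000 nM in the physicochemical assay, at which 1 of the 2 values shown sits.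

The compounds shown leave open how a methoxy or dimethylamino group in place of the amino group on the 6-aminopyridazin-3-yl ring would stand in the Rattus norvegicus assay and the physicochemical assay.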